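A few compounds are considered here, and "the series" means these few. Any claim that something is new, unique, unknown or untested is made for them only; others in the source may bear on it.

All three measured compounds were tested in a functional assay on Bel-7402 cells (Homo sapiens) for cytotoxicity, read by MTT assay, with a stated time of 72 h; a higher number here means a weaker inhibitor, a lower number a stronger inhibitor.

Compound 1, `O=C(Nc1ccc(-n2ncc3c(Cl)cccc32)cc1)Nc1ccc(Cl)c(C(F)(F)F)c1`: 2500 nM
Compound 2, `O=C(Nc1ccc(-n2ncc3c(F)cccc32)cc1)Nc1ccc(Cl)c(C(F)(F)F)c1`: 16000 nM
Compound 3, `O=C(Nc1ccc(-n2ncc3ccccc32)cc1)Nc1ccc(Cl)c(C(F)(F)F)c1`: 10600 nM

Compound 3 gives the second highest of the three numbers. Its nearest neighbour is compound 2, and that pair lies within the scatter: a 1.5-fold lower number from compound 2 to compound 3 (0.18 log units; within the scatter). Compound 1 is the only one that stands apart from it, with a 4.2-fold higher number from compound 1 to compound 3 (0.63 log units; beyond the scatter).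

Compound 4, `O=C(Nc1ccc(-n2ncc3ccncc32)cc1)Nc1ccc(Cl)c(C(F)(F)F)c1`, has not been measured. It differs from compound 3 in one place: a group of 9 heavy atoms (6 carbon, 3 nitrogen; one five-membered aromatic ring with 2 hetero atoms, one six-membered aromatic ring with 1 hetero atom) in place of a group of 9 heavy atoms (7 carbon, 2 nitrogen; one five-membered aromatic ring with 2 hetero atoms, one six-membered aromatic ring of carbon only), on an aromatic carbon. The measured steps all change a single substituent on the six-membered carbon ring of the 1H-indazol-1-yl group. Exchanging chloro for fluoro gave a 6.4-fold higher number from compound 1 to compound 2 (0.81 log units; beyond the scatter), exchanging chloro for hydrogen gave a 4.2-fold higher number from compound 1 to compound 3 (0.63 log units; beyond the scatter), and exchanging fluoro for hydrogen gave a 1.5-fold lower number from compound 2 to compound 3 (0.18 log units; within the scatter). None of these exchanges a ring carbon for a ring nitrogen, so there is no direct guide for the step to compound 4. What the measured steps do show is that only the chloro of compound 1 separates a compound from the others; the other two variants at this ring sit together.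

On that basis the step from compound 3 to compound 4 is expected to stay within the scatter, a 1.1-fold higher number from compound 3 to compound 4 (0.05 log units; within the scatter). Compound 4 is therefore estimated at 12000 nM, with a range from 4000 nM to 40000 nM.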

Compound 4, half-maximal inhibitory concentration: 4000 nM
Compound 4: the middle estimate sits 3.0-fold (0.48 log units) above what was measured; the range from low to high includes it.
By their numbers in this assay, from the lowest: compounds 1 and 4 (each within the scatter of the next); then compounds 3 and 2 (each within the scatter of the next).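

In this assay, exchanging a single carbon of the six-membered ring in the 1H-indazol-1-yl group for a nitrogen, with no substituent added, gives a 2.7-fold lower number from compound 3 to compound 4 (0.42 log units; beyond the scatter), so this ring is sensitive to a change within the ring itself and not only to what is attached to it. The comparison with the fluoro variant points the same way, with a 4.0-fold lower number from compound 2 to compound 4 (0.60 log units; beyond the scatter), whereas the comparison with the chloro variant gives a 1.6-fold higher number from compound 1 to compound 4 (0.20 log units; within the scatter). For the compounds shown here, two different changes to this ring, the chloro of compound 1 and the ring nitrogen of compound 4, therefore give numbers that cannot be told apart, so the chloro is no longer the only change that separates a compound from the rest.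

No measurement available here accounts for the behaviour of either the ring nitrogen or the chloro. On these data alone, it also remains open how a ring nitrogen would behave elsewhere in this ring, and whether a chloro, a methoxy group or an amine added to the ring of compound 4 would shift the number further.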